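From 4-fluorophenoxy to ethoxy on the shared core

The compounds below may be only part of what the source reports. "The series", "measured", "known", "first", "only" and "open" are said of these compounds alone.

In a functional assay on MCF7 cells (Homo sapiens) for inhibition, read by sulforhodamine B assay, with a stated time of 48 h, tested at 50 uM (a lower number here means less inhibition of growth, a higher number more inhibition of growth at the concentration tested), compound 1 (`COc1cc2c(cc1CC=C(C)C)C(=O)C[C@@H](c1ccc(Oc3ccc(F)cc3)cc1)O2`) gives 37% and stands lower of the two measured compounds. Compound 2 (`COc1cc2c(cc1CC=C(C)C)/C(=N/NC(N)=O)C[C@@H](c1ccc(O)cc1)O2`) gives 93% in the same test, and the gap between the two lies beyond the scatter. Compound 3 (`CCOc1ccc([C@@H]2CC(=O)c3cc(CC=C(C)C)c(OC)cc3O2)cc1`) has not yet been measured. Its difference from compound 1 is ethyl in place of 4-fluorophenyl on an oxygen on an aromatic ring and reads in words as ethyl in place of 4-fluorophenyl on an oxygen on an aromatic ring, so that 4-fluorophenoxy gives way to ethoxy. Going by the values given here, no measured pair shows this change, so the expectation rests only on the change itself and on compound 1 at 37% as its starting point. In this assay the expected step is a number 3 percentage points higher from compound 1 to compound 3 (within the scatter) and this small upward move stays within the scatter. For compound 3 the estimated value is 40% with an expected range from 20% to 62% around it.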

Compound 3, percent growth inhibition at one concentration: 57%
Beside the measured number, compound 3's estimate is 17 percentage points below it, within the range that was stated.
By their numbers in this assay, from the lowest: compound 1; then compound 3; then compound 2.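

On the oxygen on an aromatic ring of the shared core, the group in this place does matter in this assay: ethyl in place of 4-fluorophenyl reads as a number 20 percentage points higher from compound 1 to compound 3 (beyond the scatter), a modest step and the first that isolates this position. The outer aromatic ring of compound 1 is therefore not required for growth inhibition at the concentration tested, as compound 3 keeps inhibition with only ethyl on that oxygen. No measurement at hand bears on why the number rises with this change.

The compounds shown leave open whether a longer chain such as butyl, or an amine carried at the end of the ethyl chain, would move the number further. Compound 2 differs from compound 3 in more than one place, so it cannot answer this.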